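Changing the benzyl group: what to expect for compound 3

A few compounds are considered here, and "the series" means these few. Any claim that something is new, unique, unknown or untested is made for them only; others in the source may bear on it.

Measured in a functional assay on Bel-7402 cells (Homo sapiens) for antiproliferative activity, read by MTT assay, with a stated time of 72 h; a lower number here means a stronger inhibitor, a higher number a weaker inhibitor:
- Compound 1 `C=C1C(=O)O[C@H]2[C@H]1CC/C(COC(=O)Cn1cc(F)c(=O)n(Cc3ccc(C(F)(F)F)cc3)c1=O)=C\CC[C@@]1(C)O[C@@H]21`: 2250 nM
- Compound 2 `C=C1C(=O)O[C@H]2[C@H]1CC/C(COC(=O)Cn1cc(F)c(=O)n(Cc3ccc([N+](=O)[O-])cc3)c1=O)=C\CC[C@@]1(C)O[C@@H]21`: 4070 nM

Within the data shown here, only these two compounds have numbers so far. Compound 2, at 4070 nM, lies within the usual scatter of compound 1, so the two cannot be ranked. Compound 3 `C=C1C(=O)O[C@H]2[C@H]1CC/C(COC(=O)Cn1cc(F)c(=O)n(Cc3cccc(F)c3)c1=O)=C\CC[C@@]1(C)O[C@@H]21` keeps the core of compound 2 and differs in one place: 3-fluorophenyl in place of 4-nitrophenyl on a saturated chain carbon bound to an aromatic nitrogen. Put simply, 3-fluorophenyl stands in place of 4-nitrophenyl on a saturated chain carbon bound to an aromatic nitrogen.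

Among the measured compounds shown here, one measured step bears on this change: a 1.8-fold higher number from compound 1 to compound 2 (0.26 log units; within the scatter). It also swaps a group on the aromatic ring, and it stays within the scatter. For the measured compounds named here, it is only a partial guide, since no measured compound carries 3-fluorophenyl. On this evidence, no change beyond the scatter is expected in this assay, and the data favour no clear direction. The expected step is small: a 1.4-fold lower number from compound 2 to compound 3 (0.13 log units; within the scatter). For compound 3 the estimated value is 3000 nM, with an expected range from 1200 nM to 7500 nM.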

Compound 3, half-maximal inhibitory concentration: 2530 nM
Compound 3: middle estimate off by 1.2-fold (0.07 log units), on the high side; low and high end bracket the measured number.
By their numbers in this assay, from the lowest: compounds 1, 3 and 2 (each within the scatter of the next).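

In this assay, replacing 4-nitrophenyl with 3-fluorophenyl on the saturated chain carbon bound to an aromatic nitrogen gives a 1.6-fold lower number from compound 2 to compound 3 (0.21 log units; within the scatter), and replacing 4-(trifluoromethyl)phenyl with it gives a 1.1-fold higher number from compound 1 to compound 3 (0.05 log units; within the scatter). This adds a test that the earlier pair did not offer: the entering group has 7 heavy atoms and 0 hydrogen-bond acceptors, against 9 and 2 for 4-nitrophenyl, and its substituent is named at a different ring position, yet neither step leaves the scatter, so compounds 1, 2 and 3 cannot be ranked. No measurement shown here explains why these swaps leave the number within the scatter.

As far as these compounds go, these steps change the substituent and its ring position together, so the contribution of each remains unknown. From the compounds shown here alone, it also remains open whether an amine or a carboxylic acid on the aromatic ring, or a longer chain in place of the single saturated carbon linking that ring to the aromatic nitrogen, would produce a step beyond the scatter.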